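A five-membered aromatic ring exchanged for another

The compounds below may be only part of what the source reports. "The series", "measured", "known", "first", "only" and "open" are said of these compounds alone.

In an ADME assay on Caco-2 cells (Homo sapiens) for permeability, in the apical to basolateral direction (a lower number here means that the compound crosses the layer more slowly, a higher number that the compound crosses the layer faster), compound 1 `Cn1nc2c(=O)n(CC3(O)CCN(Cc4ccc(-c5cnco5)cc4Cl)CC3)cnc2c1-c1ccc(CN)cc1` gives 0.86 10^-6 cm/s while compound 2 `Cn1nc2c(=O)n(CC3(O)CCN(Cc4ccc(-c5ccco5)cc4Cl)CC3)cnc2c1-c1ccc(CNC=O)cc1` gives 0.65 10^-6 cm/s and compound 3 `CNCc1ccc(-c2c3ncn(CC4(O)CCN(Cc5ccc(-c6ccco6)cc5Cl)CC4)c(=O)c3nn2C)cc1` gives 1.06 10^-6 cm/s and these three numbers lie within the scatter of one another. Compound 4 `Cn1nc2c(=O)n(CC3(O)CCN(Cc4ccc(-c5cccs5)cc4Cl)CC3)cnc2c1-c1ccc(CN)cc1` is not yet measured. For the measured compounds named here, its difference from compound 1 is thiophen-2-yl in place of 1,3-oxazol-5-yl on an aromatic carbon and no measured step covers this exchange. Going by the values given here, the only measured step, a 1.6-fold higher number from compound 2 to compound 3 (0.21 log units; within the scatter) for methyl in place of formyl on an amine nitrogen, lies elsewhere in the structure and stays within the scatter. No change beyond the scatter is therefore expected in this assay and the estimated step is a 1.2-fold higher number from compound 1 to compound 4 (0.07 log units; within the scatter) with no firm direction. The expected value for compound 4 is 1 10^-6 cm/s within a range of 0.45 10^-6 cm/s to 2.2 10^-6 cm/s around it.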

Compound 4, apparent permeability: 0.8 10^-6 cm/s
The estimate for compound 4 lay 1.3-fold (0.10 log units) above the measured number; measured number inside the range.
By their numbers in this assay, from the lowest: compounds 2, 4, 1 and 3 (each within the scatter of the next).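

In this assay, for the compounds shown here, thiophen-2-yl in place of 1,3-oxazol-5-yl gives the first measured step at this position, a 1.1-fold lower number from compound 1 to compound 4 (0.03 log units; within the scatter), on an aromatic carbon of the ring that also carries the chloro group. The entering ring has one hetero atom and one hydrogen-bond acceptor where the leaving ring has two of each, yet the number stays within the scatter. Nothing measured here offers an explanation for this result.

All four compounds shown carry a five-membered aromatic ring at this place. As far as these compounds go, what a pyridine ring or a carboxylic acid there would do to the number remains open.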